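The source may hold more compounds than are shown below. What is called first, only, known or untested is meant among the compounds shown, and "the series" means these compounds.

Three compounds share one core and differ only in a single side group. Compound 1 `CC1=CC(=O)CC(C)(C)[C@@]1(O)/C=C/C(C)=C\C(=O)N[C@@H](CC(N)=O)C(=O)O` carries a carbamoyl group there, and in a functional assay on the whole organism for inhibition, with Oryza sativa as the target, with a stated time of 24 h (on this read-out higher numbers stand for weaker inhibition and lower numbers for stronger inhibition), compound 1 gives 9300 nM. Compound 2 `CC1=CC(=O)CC(C)(C)[C@@]1(O)/C=C/C(C)=C\C(=O)N[C@@H](CCC(N)=O)C(=O)O` stretches that group to carbamoylmethyl, and in this assay compound 2 gives 8300 nM. Compound 3 `CSCC[C@H](NC(=O)/C=C(C)\C=C\[C@@]1(O)C(C)=CC(=O)CC1(C)C)C(=O)O` bears a (methylsulfanyl)methyl group instead; in this assay compound 3 gives 16000 nM, the highest of the three numbers, although a 1.7-fold higher number from compound 1 to compound 3 (0.24 log units; within the scatter) and a 1.9-fold higher number from compound 2 to compound 3 (0.29 log units; within the scatter) both stay within the scatter, as does a 1.1-fold lower number from compound 1 to compound 2 (0.05 log units; within the scatter). Compound 4 `CC1=CC(=O)CC(C)(C)[C@@]1(O)/C=C/C(C)=C\C(=O)N[C@@H](CC(=O)O)C(=O)O` is the next step: carboxy in place of (methylsulfanyl)methyl on a saturated chain carbon, two bonds along the chain from an amide-type nitrogen and a carbonyl carbon. Every earlier swap of one small side group for another left the number inside the scatter, and this swap is of the same kind, so a 1.6-fold lower number from compound 3 to compound 4 (0.20 log units; within the scatter) is expected to be small, a drift back toward the middle of the three measured numbers rather than a clear move in either direction. Compound 4 is therefore estimated at 10000 nM, with a range from 4000 nM to 25000 nM.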

Compound 4, half-maximal inhibitory concentration: 6400 nM
Compound 4: the middle estimate sits 1.6-fold (0.19 log units) above what was measured; low and high end bracket the measured number.
By their numbers in this assay, from the lowest: compounds 4, 2, 1 and 3 (each within the scatter of the next, the first and the last beyond it).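

Among the compounds shown here, at this position, on a saturated chain carbon, a 2.5-fold lower number from compound 3 to compound 4 (0.40 log units; beyond the scatter) is the first step in this assay to pass beyond the scatter, which shows that the side group can move the number, though only modestly. The carboxy group does not separate from the two amide side groups: a 1.3-fold lower number from compound 2 to compound 4 (0.11 log units; within the scatter) and a 1.5-fold lower number from compound 1 to compound 4 (0.16 log units; within the scatter) both stay within the scatter, the latter being hydroxy in place of amino on a carbonyl carbon, so only the (methylsulfanyl)methyl compound stands apart from compound 4. Nothing available explains this shift.

As far as these compounds go, whether carboxyethyl, a longer chain ending in the same acid, would stay with compound 4 remains open. So does where an amine such as 4-aminobutyl, or a phenyl ring, would fall at this position.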